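Sulfonyl replacement on the aryl ring of compound 1

The compounds below may be only part of what the source reports. "The series", "measured", "known", "first", "only" and "open" are said of these compounds alone.

Compound 1 `CC(C)OC(=O)N1CCC(Oc2ncnc3c2CCN3c2ccc(S(C)(=O)=O)cc2)CC1` is the reference point in this pair. In a functional assay on CHO-K1 cells for agonist activity at Glucose-dependent insulinotropic receptor (Homo sapiens), read by a luciferase reporter, with a stated time of 5 h (on this read-out higher numbers stand for an effect only at larger amounts of compound and lower numbers for an effect already at smaller amounts), compound 1 gives 126 nM. Compound 2 `Cc1nc(OC2CCN(C(=O)OC(C)(C)C)CC2)c2c(n1)N(c1ccc(S(C)(=O)=O)cc1F)CC2` carries a different ester and a fluorine on its aryl ring and a methyl on the core, and in this assay compound 2 gives 126 nM; the two values lie level at the digits shown, so compound 1 stands within the scatter of its only measured neighbour and no order between them can be read from these numbers.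

Compound 3 `CC(C)OC(=O)N1CCC(Oc2ncnc3c2CCN3c2ccc([S+]([O-])N(C)C)cc2)CC1` is not yet measured. It differs from compound 1 in a single place: a group of 5 heavy atoms (2 carbon, 1 nitrogen, 1 oxygen, 1 sulfur; no ring) in place of a group of 4 heavy atoms (1 carbon, 2 oxygen, 1 sulfur; no ring), on an aromatic carbon The new group sits on an aromatic carbon of a six-membered aromatic ring of carbon only, para to a large group.

Within the data shown here, no measured step of this kind exists, so the expected size rests only on the two values above and on the change itself. A modest loss is expected, with the step from compound 1 to compound 3 estimated as a 2.2-fold higher number from compound 1 to compound 3 (0.35 log units; beyond the scatter), because compound 1 stands at 126 nM and nothing in the data argues for a gain. Compound 3 is thus expected to give about 280 nM in this assay, within a range of 90 nM to 900 nM.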

Compound 3, half-maximal effective concentration: 501 nM
The estimate for compound 3 lay 1.8-fold (0.25 log units) below the measured number; measured number inside the range.
By their numbers in this assay, from the lowest: compounds 1 and 2 (each within the scatter of the next); then compound 3.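

In this assay, among these compounds, the exchange of methylsulfonyl for the new group of 5 heavy atoms, on an aromatic carbon para to a large group, gives a 4.0-fold higher number from compound 1 to compound 3 (0.60 log units; beyond the scatter), the first step that lies beyond the scatter. This position is therefore not indifferent to the group it carries, even though the change is small in size. Neither group contains a ring or a net charge, and their counts of hydrogen-bond donors and acceptors match, so these computed features alone do not account for the difference in this assay, and no measurement is available that explains the step.

Going by these compounds, with a single exchange at this position, compound 1 at 126 nM remains the only reference for judging other groups, and it is open whether a nitrile, a carboxylic acid or a simple amine on the same aromatic carbon would hold that value or move further from it. On these data alone, it is also open whether the same step would appear on the background of compound 2, which differs from compound 1 in its ester, its aryl fluorine and its core methyl.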